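The source may report more compounds than this note shows. Statements on the series, on what has been measured and on what is new or still open speak of the compounds shown alone.

In a toxicity assay on HUVEC cells (Homo sapiens) for inhibition (a higher number here means a weaker inhibitor of growth, a lower number a stronger inhibitor of growth), compound 1 (`Cc1ccc(C)c(N2CCN(C(=O)c3oc(C)nc3-c3ccccc3)CC2)c1`) gives 1.73 ug/mL and compound 2 (`COc1cc(OC)cc(N2CCN(C(=O)c3oc(C)nc3-c3cccc(F)c3)CC2)c1`) gives 0.126 ug/mL as the lower of the two numbers. That gap lies beyond the usual scatter, so compound 2 is the stronger inhibitor of growth in this pair. Compound 3 (`COc1cc(OC)cc(N2CCN(C(=O)c3oc(C)nc3-c3ccccc3)CC2)c1`) has not yet been measured. It differs from compound 2 by one change (hydrogen in place of fluoro on an aromatic carbon), with hydrogen in place of fluoro on an aromatic carbon, so that 3-fluorophenyl becomes phenyl. Within the data shown here, no measured pair shows this change on its own, and the data therefore give no direct guide to its size. A small step in this assay toward a higher number is expected, lying near the edge of the scatter, with compound 2 at 0.126 ug/mL as the starting point and the closest measured neighbour. The step expected is a 2.0-fold higher number from compound 2 to compound 3 (0.30 log units; within the scatter) on this estimate. For compound 3 the estimated value is 0.25 ug/mL (expected range 0.07 ug/mL to 0.9 ug/mL).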

Compound 3, concentration for 50% growth inhibition: 0.319 ug/mL
Compound 3: the middle estimate sits 1.3-fold (0.11 log units) below what was measured, within the range that was stated.
By their numbers in this assay, from the lowest: compound 2; then compound 3; then compound 1.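

In this assay, among these compounds, hydrogen in place of fluoro on the aromatic carbon gives a 2.5-fold higher number from compound 2 to compound 3 (0.40 log units; beyond the scatter), the first reading of this change on its own, and it shows that the 3-fluorophenyl group goes with the stronger inhibitor of growth in this pair. Compound 3 also separates the two differences that lay together between compound 1 and compound 2: with the phenyl group held constant, 3,5-dimethoxyphenyl in place of 2,5-dimethylphenyl on the amine nitrogen in the ring gives a 5.4-fold lower number from compound 1 to compound 3 (0.73 log units; beyond the scatter), so the gap first seen in that pair reflects a step beyond the scatter at each of the two places. Nothing in the data given accounts for the size of either step.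

On these data alone, whether chloro, a nitrile or a trifluoromethyl group on the same aromatic carbon would move the number further in either direction remains open, as does the effect of fluoro on the other carbons of that ring. It is also unknown whether the step from fluoro to hydrogen keeps its size when the 2,5-dimethylphenyl group stands on the amine nitrogen.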